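The compounds below may be only part of what the source reports. "The series", "measured", "known", "first", "only" and "open" are said of these compounds alone.

Working notes on the series. Compound 1 `C=CCc1cc(C(C)=O)c(O)cc1OCCCCCCCC#N` is the starting point; in an assay on isolated protein for binding affinity to leukotriene B4 receptor 1 (Homo sapiens), tested at 1 uM (a lower number here means less inhibition, a higher number more inhibition at the concentration tested (going by the name of the read-out)), compound 1 gives 52%. Within the data shown here, compound 2 `CCc1cc(C(C)=O)c(O)cc1OCCCCCCC(C)(C)c1nnn[nH]1` differs from compound 1 in more than one place, so no single step joins the two; in this assay compound 2 gives 67%, which leaves compound 1 with the lower of the two numbers, compound 2 standing above it beyond the usual scatter. Compound 3 `C=CCc1cc(C(C)=O)c(O)cc1OCCCCCC(=O)OC` has not yet been run in this assay. Its change from compound 1 is methoxycarbonyl in place of 2-cyanoethyl on a saturated chain carbon, five bonds along the chain from an oxygen on an aromatic ring. Among the measured compounds shown here, no measured pair in the set isolates this change, so its size has no direct anchor in the data. The step from compound 1 to compound 3 is expected to be modest and, if anything, downward, at a number 7 percentage points lower from compound 1 to compound 3 (within the scatter). Compound 3 is accordingly estimated at 45% in this assay, with a range from 20% to 70%, kept wide for want of any measured analogue of the change.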

Compound 3, a percentage reported as inhibition, at one concentration (the size of the read-out at that concentration, not a potency): 65%
Estimate against measurement, compound 3: 20 percentage points below, and the stated range covers the measured number.
By their numbers in this assay, from the lowest: compound 1; then compounds 3 and 2 (each within the scatter of the next).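

In this assay, the series now has its first step that changes one place only: methoxycarbonyl in place of 2-cyanoethyl, on a saturated chain carbon, five bonds along the chain from an oxygen on an aromatic ring, gives a number 13 percentage points higher from compound 1 to compound 3 (beyond the scatter) with the rest of the structure unchanged. This shows that the group at this position bears on the inhibition read at the concentration tested, and that the nitrile of compound 1 is not needed there for that inhibition. Nothing at hand accounts for the step, so it stands as an observation only.

The compounds shown leave open how a carboxylic acid or a primary amide would read at the same place. They also leave open whether the methoxycarbonyl group keeps this step on a longer chain.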